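Adding a methyl to the benzylic carbon of compound 1

A few compounds are considered here, and "the series" means these few. Any claim that something is new, unique, unknown or untested is made for them only; others in the source may bear on it.

Compound 1 `c1ccc(CNCC2CCN(CCCc3c[nH]c4ccc(-n5cnnc5)cc34)CC2)cc1` is a triazole-bearing member of this series; in an assay on CHO cells for displacement of a labelled ligand from 5-hydroxytryptamine receptor 1D (Homo sapiens) (a higher number here means a weaker inhibitor, a lower number a stronger inhibitor), compound 1 gives 1.6 nM. Among the three measured compounds it holds the second highest number. Compound 2 `OC[C@H](NC1CCN(CCCc2c[nH]c3ccc(-n4ccnc4)cc23)CC1)c1ccccc1` gives 0.7 nM, a lower number than that of compound 1, while compound 3 `C[C@@H](NC1CCN(CCCc2c[nH]c3ccc(-n4ccnc4)cc23)CC1)c1ccccc1` gives 4.2 nM, a higher one, so compound 1 sits between the two.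

Compound 4 `C[C@H](NCC1CCN(CCCc2c[nH]c3ccc(-n4cnnc4)cc23)CC1)c1ccccc1` differs from compound 1 in one place: methyl in place of hydrogen on a saturated chain carbon bound to an amine nitrogen and an aromatic carbon. For the measured compounds named here, no measured pair shows exactly this change. Going by the values given here, the only step within the data touches the same carbon in a related way: a 6.0-fold higher number from compound 2 to compound 3 (0.78 log units; beyond the scatter). There, however, a hydroxymethyl was swapped for a methyl rather than a hydrogen, and the amine sat directly on the piperidine, so it is only a rough guide. Its direction suggests that adding a methyl without an accompanying hydroxyl is not rewarded.

He therefore expects the move from compound 1 to compound 4 to be small, most likely a slight weakening and at most a modest one, so that compound 4 is estimated at 2.5 nM, with a range from 0.8 nM to 8 nM, and an expected step of a 1.6-fold higher number from compound 1 to compound 4 (0.19 log units; within the scatter).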

Compound 4, half-maximal inhibitory concentration: 4.4 nM
Estimate against measurement, compound 4: 1.8-fold (0.25 log units) below, and the stated range covers the measured number.
By their numbers in this assay, from the lowest: compound 2; then compound 1; then compounds 3 and 4 (each within the scatter of the next).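

In this assay, the change from benzyl to 1-phenylethyl gives a 2.8-fold higher number from compound 1 to compound 4 (0.44 log units; beyond the scatter), so this carbon, a saturated chain carbon bound to an amine nitrogen and an aromatic carbon, does not tolerate the added methyl without a measurable cost. This is the first pair shown in which a hydrogen alone leaves and a methyl alone enters, which separates the effect of that methyl from the hydroxymethyl exchange behind the earlier step, a 6.0-fold higher number from compound 2 to compound 3 (0.78 log units; beyond the scatter), and both of these changes at the benzylic carbon raise the number. No measurement given here accounts for the rise seen with the methyl.

The compounds shown leave open whether the opposite stereochemical arrangement at this carbon would give a similar number, as compound 4 represents only one arrangement. They also leave open how an ethyl or a hydroxymethyl at this same carbon would compare with the methyl, and so whether the number keeps rising with a longer chain or falls again with a hydroxyl on the added group.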